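This account rests on a few compounds, and the source may have more. Where it says the series, first, only, none or still open, it means among the compounds named here.

Measured in a functional assay on KYSE-450 cells (Homo sapiens) for inhibition, read by CCK-8 assay, with a stated time of 48 h; a lower number here means a stronger inhibitor, a higher number a weaker inhibitor:
- Compound 1 `COc1ccc(CN(C(=O)CSC(=S)N2CCN(C)CC2)c2cc(OC)c(OC)c(OC)c2)cc1`: 1250 nM
- Compound 2 `CCN1CCN(C(=S)SCC(=O)N(Cc2ccc(OC)cc2)c2cc(OC)c(OC)c(OC)c2)CC1`: 3070 nM
- Compound 3 `COc1ccc(CN(C(=O)CSC(=S)N2CCN(C(C)=O)CC2)c2cc(OC)c(OC)c(OC)c2)cc1`: 370 nM

Compound 3 holds the lowest number of the three, and its gaps to the other two lie beyond the scatter. Compound 4 `COc1ccc(CN(C(=O)CSC(=S)N2CCN(C(=O)OC(C)(C)C)CC2)c2cc(OC)c(OC)c(OC)c2)cc1` differs from it by tert-butoxy in place of methyl on a carbonyl carbon, acetyl to tert-butoxycarbonyl: tert-butoxy in place of methyl on a carbonyl carbon. For the measured compounds named here, no measured step makes this exact change, so the evidence is indirect. Putting acetyl on the amine nitrogen in a ring gave a 3.4-fold lower number from compound 1 to compound 3 (0.53 log units; beyond the scatter) and an 8.3-fold lower number from compound 2 to compound 3 (0.92 log units; beyond the scatter), and compound 4 keeps that carbonyl. Methyl in place of hydrogen on the saturated chain carbon, however, gave a 2.5-fold higher number from compound 1 to compound 2 (0.39 log units; beyond the scatter), a move towards a higher number. Taken together, these steps suggest that some of the gain may be kept but not all of it. A modest rise is therefore expected in this assay, with an estimated change of a 1.6-fold higher number from compound 3 to compound 4 (0.21 log units; within the scatter). The expected value for compound 4 is 600 nM, within an estimated range of 170 nM to 2000 nM.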

Compound 4, half-maximal inhibitory concentration: 250 nM
For compound 4 the middle estimate is 2.4-fold (0.38 log units) above the measured one, within the range that was stated.
By their numbers in this assay, from the lowest: compounds 4 and 3 (each within the scatter of the next); then compound 1; then compound 2.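

In this assay, tert-butoxy in place of methyl on a carbonyl carbon gives a 1.5-fold lower number from compound 3 to compound 4 (0.17 log units; within the scatter), so at this position 5 heavy atoms stand in for 1 with no change that can be told from the scatter. On the amine nitrogen in a ring, tert-butoxycarbonyl keeps the advantage over the simple chains that acetyl showed, with a 5.0-fold lower number from compound 1 to compound 4 (0.70 log units; beyond the scatter) in place of methyl and a 12-fold lower number from compound 2 to compound 4 (1.09 log units; beyond the scatter) in place of ethyl, the second of these being large. Nothing measured here accounts for these numbers.

As far as these compounds go, whether a benzoyl group, a methanesulfonyl group or a plain hydrogen on that nitrogen would sit with compound 3 and compound 4 remains open. So does whether a longer chain on the carbonyl carbon would keep the number at this level.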